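The source may report more compounds than this note shows. Statements on the series, on what has been measured and on what is new or still open speak of the compounds shown alone.

Compound 1, `CC(=O)Nc1ccn(C2OC(CO[Si](C)(C)C(C)(C)C)C(C#N)C2O[Si](C)(C)C(C)(C)C)c(=O)n1`, gives > 3.2 ug/mL in a functional assay on cells (Fibroblast, Mus musculus) for cytotoxicity; on this read-out higher numbers stand for lower toxicity in this test and lower numbers for higher toxicity in this test.
Compound 2, `CC(C)(C)[Si](C)(C)OC[C@H]1O[C@@H](n2cnc3c(N)ncnc32)[C@H](O[Si](C)(C)C(C)(C)C)[C@@H]1C#N`, gives 8 ug/mL in this assay.
Compound 3, `Cc1cn([C@H]2C[C@@H](C#N)[C@@H](CO)O2)c(=O)[nH]c1=O`, gives > 250 ug/mL in this assay.

The value for compound 1 is a limit of the test, not a number. The value for compound 3 is likewise a limit, not a number, and it sits at the limit of > 250 ug/mL in this assay, at which 1 of the 3 values shown sits. Compound 2 is the only one of the three with a measured number. For the measured compounds named here, compound 3 therefore stands at the least toxic edge of what the test could show, and no step between measured compounds has been counted here.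

Compound 4, `Cc1cn([C@H]2C[C@H](C#N)[C@@H](CO)O2)c(=O)[nH]c1=O`, has not yet been measured in this assay. Its difference from compound 3 is small: the two compounds have the same atoms and bonds and differ only in configuration as drawn: 1 of 3 stereo elements differ; a stereocentre at a saturated ring carbon is drawn S in compound 3 and R in compound 4. With compound 3 already at a limit, the step is expected to stay within the usual scatter, with no direction to be read from it, so a number no higher from compound 3 to compound 4 (the limit leaves the size open) is the expected outcome. Compound 4 is accordingly estimated at 250 ug/mL, with a range from 80 ug/mL to 500 ug/mL, most likely again reported only as a limit.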

Compound 4, minimum cytotoxic concentration: 80 ug/mL
Beside the measured number, compound 4's estimate is 3.1-fold (0.49 log units) above it; the measured number falls inside the stated range.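

In this assay the result gives an at least 3.1-fold lower number from compound 3 to compound 4 (0.49 log units; beyond the scatter), so the configuration drawn at a saturated ring carbon is enough on its own to move the read-out beyond the usual scatter. Going by these compounds, the value of compound 3 is a limit, not a number, so the full size of the step stays open: the limit of > 250 ug/mL in this assay, at which 1 of the 4 values shown sits. This is the first step among these compounds, and with nothing entering or leaving, it rests on that stereocentre alone: the fact that compounds 3 and 4 differ only in the configuration as drawn.

The compounds shown leave open whether the same change in configuration would matter with a group other than the nitrile on that carbon, such as an amine or a carboxylic acid. They also leave open whether it would carry over to the silyl-bearing compound 1 and compound 2.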